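Sulfonamide nitrogen substituents and maximal response

This account rests on a few compounds, and the source may have more. Where it says the series, first, only, none or still open, it means among the compounds named here.

The series shares one core and differs at the sulfonyl group. Compound 1 `CC1(C)C=C(n2ccccc2=O)c2cc(S(=O)(=O)N=[N+]=[N-])ccc2O1` gives 77.2% in a functional assay on the whole organism (trachea) with Rattus norvegicus as the target; a higher number here means a larger maximal response, a lower number a smaller maximal response. Compound 2 `CC1(C)C=C(n2ccccc2=O)c2cc(S(N)(=O)=O)ccc2O1` gives 92.1%, and compound 3 `CCNS(=O)(=O)c1ccc2c(c1)C(n1ccccc1=O)=CC(C)(C)O2` gives 87%. Compound 3 sits second highest of the three: it is nearest to compound 2, with a number 5.1 percentage points lower from compound 2 to compound 3 (within the scatter), and furthest from compound 1, with a number 9.8 percentage points higher from compound 1 to compound 3 (within the scatter); both gaps lie within the scatter.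

The next compound is compound 4 `CC1(C)C=C(n2ccccc2=O)c2cc(S(=O)(=O)Nc3ccc(C#N)cc3)ccc2O1`. Its change from compound 3 is 4-cyanophenyl in place of ethyl on a sulfonamide nitrogen.

Within the data shown here, two measured steps touch the same sulfonyl group. The step of a number 14.9 percentage points higher from compound 1 to compound 2 (beyond the scatter) is the only one beyond the scatter. The step of a number 5.1 percentage points lower from compound 2 to compound 3 (within the scatter), which also alters the sulfonamide nitrogen, stays within the scatter. Among the measured compounds shown here, no measured step carries an aromatic ring onto that nitrogen, so the change to compound 4 is larger than any tried so far, and its effect on this assay cannot be drawn from a direct precedent.

Given the flat response of this assay to substitution on the sulfonamide nitrogen, compound 4 is expected to stay near compound 3, with a number 3 percentage points lower from compound 3 to compound 4 (within the scatter) not beyond the scatter. The estimate for compound 4 is 84%, within a range of 68% to 98%.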

Compound 4, largest response reached (Emax), in percent of the reference or control that the assay uses: 90.8%
The estimate for compound 4 lay 6.8 percentage points below the measured number; measured number inside the range.
By their numbers in this assay, from the lowest: compounds 1, 3, 4 and 2 (each within the scatter of the next, the first and the last beyond it).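

Carrying an aromatic ring on the sulfonamide nitrogen leaves this assay essentially unmoved: 4-cyanophenyl in place of ethyl gives a number 3.8 percentage points higher from compound 3 to compound 4 (within the scatter) and 4-cyanophenyl in place of hydrogen gives a number 1.3 percentage points lower from compound 2 to compound 4 (within the scatter), so hydrogen, ethyl and 4-cyanophenyl on that nitrogen cannot be told apart in this assay, and the flat picture now covers a much larger substituent than ethyl. Against the azido compound the picture is mixed: (4-cyanophenyl)amino in place of azido gives a number 13.6 percentage points higher from compound 1 to compound 4 (beyond the scatter), which places compound 4 with compound 2 as separated from compound 1, while compound 3 goes against this with a number 9.8 percentage points higher from compound 1 to compound 3 (within the scatter). Nothing among the data given here bears on the reason for this flat response.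

The series leaves open whether the same tolerance holds for a longer alkyl chain, a carboxylic acid on the phenyl ring or an aminoalkyl group on the sulfonamide nitrogen. From the compounds shown here alone, with only the 4-cyanophenyl ring as an aromatic example, it also remains open whether an unsubstituted phenyl or a 4-methoxyphenyl group would give the same maximal response.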